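This account rests on a few compounds, and the source may have more. Where it says the series, first, only, none or still open, it means among the compounds named here.

Measured in a functional assay on SW480 cells (Homo sapiens) for antiproliferative activity, read by MTT assay, with a stated time of 48 h; on this read-out lower numbers stand for stronger inhibition and higher numbers for weaker inhibition:
- Compound 1 `CCCCCC(CCO)n1cnc2c(NC)ncnc21`: > 50000 nM, a limit of the assay.
- Compound 2 `CCCCCCC(CCO)n1cnc2c(NC)ncnc21`: > 50000 nM, a limit of the assay.
- Compound 3 `CCCCCCCCC(CCO)n1cnc2c(OC)ncnc21`: 24600 nM.

For the measured compounds named here, compound 3 is the only compound here with an actual number, 24600 nM. What remains is the limit of > 50000 nM in this assay, at which 2 of the 3 values shown sit.

Compound 4 `CCCCCCCCC(CCO)n1cnc2c(NC)ncnc21` keeps the chain of compound 3, but methylamino stands in place of methoxy on an aromatic carbon (methylamino in place of methoxy on an aromatic carbon). Going by the values given here, no measured step makes this swap. Among the compounds with values here, the one measured step, a step that the two limits leave unreadable from compound 1 to compound 2, concerns the chain and offers no size to carry over.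

Compounds 1 and 2 do carry methylamino, but on shorter chains than compound 3, so they are only a weak hint. Hence no step beyond the scatter is expected in this assay, with a slight lean towards weaker inhibition. The estimated step is a 1.3-fold higher number from compound 3 to compound 4 (0.11 log units; within the scatter).

For compound 4 the estimate is 32000 nM, with an expected range from 13000 nM to 70000 nM.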

Compound 4, half-maximal inhibitory concentration: 3770 nM
The estimate for compound 4 lay 8.5-fold (0.93 log units) above the measured number; the whole stated range lies above it.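

In this assay, with the chain held the same, methylamino in place of methoxy gives a 6.5-fold lower number from compound 3 to compound 4 (0.81 log units; beyond the scatter), so swapping one oxygen for one nitrogen at this aromatic carbon, which also adds a hydrogen-bond donor, is enough to move the read-out clearly. With methylamino kept, the longer chain also counts, giving an at least 13-fold lower number from compound 2 to compound 4 (1.12 log units; beyond the scatter) and an at least 13-fold lower number from compound 1 to compound 4 (1.12 log units; beyond the scatter). Both of these steps are only minimum sizes, since each starts from a limit of the assay rather than a number: the limit of > 50000 nM in this assay, at which 2 of the 4 values shown sit.

Still open, from the compounds shown here alone, is whether a plain amino group or a dimethylamino group at this aromatic carbon would behave like methylamino, which would help show what the added donor contributes. Also open, going by these compounds, is whether a chain longer than that of compound 4 would lower the number further.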